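Methylsulfonyl in place of fluoro on the amide aryl carbon

The compounds below may be only part of what the source reports. "The series", "measured", "known", "first", "only" and "open" are said of these compounds alone.

Measured compounds:
compound 1 `O=C(Nc1ccc(Cl)c(-c2nnc3c(Cl)cccn23)c1)c1ccc(F)cc1Cl` — > 100000 nM
compound 2 `O=C(Nc1ccc(Cl)c(-c2nnc3c(Cl)cccn23)c1)c1ccccn1` — > 100000 nM
compound 3 `O=C(Nc1ccc(Cl)c(-c2nnc3c(Cl)cccn23)c1)c1cccc(Cl)c1` — 68400 nM

In a functional assay on AN3-CA cells (Homo sapiens) for antiproliferative activity, read by MTT assay, with a stated time of 72 h (on this read-out higher numbers stand for weaker inhibition and lower numbers for stronger inhibition), compound 1 gives only a limit, > 100000 nM. Compound 2 likewise returns only a limit in this assay. Within the data shown here, compound 3 is the one member with a number, and the step from it is an at least 1.4-fold lower number from compound 1 to compound 3 (0.16 log units; that floor lies within the scatter). The pair of limits makes a step that the two limits leave unreadable from compound 1 to compound 2, and an at least 1.4-fold lower number from compound 2 to compound 3 (0.16 log units; that floor lies within the scatter) rests on the same floor. Two of the three values sit at the limit of > 100000 nM in this assay, at which 2 of the 3 values shown sit, so the measured range tells little about direction.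

Compound 4 `CS(=O)(=O)c1ccc(C(=O)Nc2ccc(Cl)c(-c3nnc4c(Cl)cccn34)c2)c(Cl)c1` differs from compound 1 in one place: methylsulfonyl in place of fluoro on an aromatic carbon. No measured step involves a methylsulfonyl group, so nothing among the steps shown bears directly on this change; the steps that exist are all small or unreadable.

Compound 4 is therefore expected to stay near the limit, with a number no higher from compound 1 to compound 4 (the limit leaves the size open) meaning no step beyond the scatter. The estimated value for compound 4 is 100000 nM, expected between 30000 nM and 300000 nM.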

Compound 4, half-maximal inhibitory concentration: > 100000 nM
Compound 4 gave a limit, no number; the forecaster's own chance of this, stated with the estimate: 55%; the middle value lies on the limit itself.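

In this assay compound 4 gives > 100000 nM, a limit, and compound 1 is also held at a limit, so no step can be read between compound 1 and compound 4. Left open is whether methylsulfonyl in place of fluoro moves the value at all, with most of the series resting on one limit: the limit of > 100000 nM in this assay, at which 3 of the 4 values shown sit.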